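A few compounds are considered here, and "the series" means these few. Any claim that something is new, unique, unknown or untested is made for them only; others in the source may bear on it.

Measured in a physicochemical assay for lipophilicity, read by HPLC, measured as octanol-water partition, at pH 7.4; on this read-out lower numbers stand for lower lipophilicity and higher numbers for higher lipophilicity:
Compound 1 `CC1(C)C[C@@H](CN([C@H](CCC(F)(F)F)C(N)=O)S(=O)(=O)c2ccc(Cl)cc2)O1`: 3.8
Compound 2 `NC(=O)[C@@H](CCC(F)(F)F)N(C[C@@H]1CCCCO1)S(=O)(=O)c1ccc(Cl)cc1`: 4.3

Of the two, compound 2 is highest at 4.3. Compound 3 `NC(=O)[C@@H](CCC(F)(F)F)N(C[C@@H]1CCCOC1)S(=O)(=O)c1ccc(Cl)cc1` differs from it as follows: oxan-3-yl in place of oxan-2-yl on a saturated chain carbon bound to a sulfonamide nitrogen. In words, oxan-3-yl stands in place of oxan-2-yl on a saturated chain carbon bound to a sulfonamide nitrogen. For the measured compounds named here, the only measured step, a number 0.50 log units higher from compound 1 to compound 2 (beyond the scatter), is modest and exchanges a different group at that place, so it bears on this change only indirectly. Going by the values given here, no measured pair makes this exact exchange. A slight fall, within the scatter, is therefore expected, and the estimated step is a number 0.20 log units lower from compound 2 to compound 3 (within the scatter). For compound 3 the expected value is 4.1, with an estimated range of 3.7 to 4.4.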

Compound 3, distribution coefficient: 3.7
Estimate against measurement, compound 3: 0.40 log units above, within the range that was stated.
By their numbers in this assay, from the lowest: compounds 3 and 1 (each within the scatter of the next); then compound 2.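

In this assay, oxan-3-yl in place of oxan-2-yl gives a number 0.60 log units lower from compound 2 to compound 3 (beyond the scatter) even though the two groups have the same atoms, so at this place the read-out depends on how the ring is joined and not on its atom count alone. Oxan-3-yl in place of 4,4-dimethyloxetan-2-yl gives a number 0.10 log units lower from compound 1 to compound 3 (within the scatter) and thus leaves those two groups unseparated. Nothing available accounts for the difference between the two oxane groups. As far as these compounds go, what oxan-4-yl or a piperidine amine would give at this place remains open, as does whether the oxan-2-yl to oxan-3-yl difference holds on another core.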